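From an Aromatic Amide to an Acetamide

The source may report more compounds than this note shows. Statements on the series, on what has been measured and on what is new or still open speak of the compounds shown alone.

In a functional assay on MKN-45 cells (Homo sapiens) for cytotoxicity (a higher number here means a weaker inhibitor, a lower number a stronger inhibitor), compound 1 (`COc1ccc(S(=O)(=O)N2CCc3cccc(NS(=O)(=O)c4ccc(F)cc4)c32)cc1`), with (4-fluorophenyl)sulfonyl on the nitrogen, gives 890 nM as its reading. With a carbonyl there instead, compound 2 (`COc1ccc(S(=O)(=O)N2CCc3cccc(NC(=O)c4cccs4)c32)cc1`) gives 31 nM and compound 3 (`COc1ccc(S(=O)(=O)N2CCc3cccc(NC(=O)c4ccc(F)cc4)c32)cc1`) gives 45 nM as theirs. Compound 3 therefore sits within the scatter of compound 2 and far under compound 1. Exchanging the sulfonyl for a carbonyl moved the number strongly (a 20-fold lower number from compound 1 to compound 3 (1.30 log units; beyond the scatter) and a 29-fold lower number from compound 1 to compound 2 (1.46 log units; beyond the scatter)), while exchanging the ring on the carbonyl did not (a 1.5-fold higher number from compound 2 to compound 3 (0.16 log units; within the scatter)).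

Compound 4 (`COc1ccc(S(=O)(=O)N2CCc3cccc(NC(C)=O)c32)cc1`) keeps the carbonyl but has methyl in place of 4-fluorophenyl on a carbonyl carbon. Going by the values given here, no measured compound lacks a ring at that place, so the ring exchange (a 1.5-fold higher number from compound 2 to compound 3 (0.16 log units; within the scatter)) is only a weak guide and the expectation stays loose. In this assay the expected result is a higher number (a 5.6-fold higher number from compound 3 to compound 4 (0.74 log units; beyond the scatter)) from a step smaller than the sulfonyl exchange. For compound 4 the estimate is 250 nM (expected range 60 nM to 1200 nM).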

Compound 4, half-maximal inhibitory concentration: 61 nM
Compound 4: the middle estimate sits 4.1-fold (0.61 log units) above what was measured; the range from low to high includes it.
By their numbers in this assay, from the lowest: compounds 2, 3 and 4 (each within the scatter of the next); then compound 1.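

Swapping the ring on the carbonyl carbon for methyl leaves the reading in this assay within the scatter (a 1.4-fold higher number from compound 3 to compound 4 (0.13 log units; within the scatter); a 2.0-fold higher number from compound 2 to compound 4 (0.29 log units; within the scatter)), so neither 4-fluorophenyl nor thiophen-2-yl is needed at this place to keep a reading of this size. The acetyl group alone still carries the large difference from the sulfonyl compound (a 15-fold lower number from compound 1 to compound 4 (1.16 log units; beyond the scatter)), which ties that difference, across these four compounds, to the carbonyl and not to any ring attached to it. Nothing available explains either observation.

Going by these compounds, it remains open whether methylsulfonyl on the same nitrogen would read like compound 1, which would show whether the sulfonyl itself matters or its aromatic ring does. On these data alone, it is also open whether a longer chain, an amine or a carboxylic acid on the carbonyl carbon would keep the reading.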